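Methyl in place of chloro on the azetidine amide

The source may report more compounds than this note shows. Statements on the series, on what has been measured and on what is new or still open speak of the compounds shown alone.

The account follows two measured compounds in an assay on Sf9 cells for inhibition of Amine oxidase [flavin-containing] A (Homo sapiens), with stated times of 15 min and 60 min; on this read-out lower numbers stand for stronger inhibition and higher numbers for weaker inhibition. Among the measured compounds shown here, compound 2 `NC(=O)[C@@H]1CCN1Cc1ccc(OCc2cccc(F)c2)cc1Cl` gives 2130 nM, which is the only number reported. Compound 1 `Cc1cc(OCc2cccc(F)c2)ccc1CN[C@@H](C)C(N)=O` gives > 10000 nM, a limit of this assay rather than a number, as the limit of > 10000 nM in this assay, at which 1 of the 2 values shown sits, shows. For the measured compounds named here, no step between measured compounds is available, since compound 1 and compound 2 differ in more than one place. Compound 3 `Cc1cc(OCc2cccc(F)c2)ccc1CN1CC[C@H]1C(N)=O` has not yet been measured in this assay. It differs from compound 2 by methyl in place of chloro on an aromatic carbon. Compound 1 also carries a methyl group, and in this assay compound 1 gives > 10000 nM, a limit. Compound 3 is therefore expected to be somewhat weaker than compound 2, with an estimate of 4500 nM and a range from 1500 nM to 15000 nM. The expected step is a 2.1-fold higher number from compound 2 to compound 3 (0.32 log units; beyond the scatter).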

Compound 3, half-maximal inhibitory concentration: 8650 nM
Beside the measured number, compound 3's estimate is 1.9-fold (0.28 log units) below it; the measured number falls inside the stated range.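

In this assay, among the compounds shown here, methyl in place of chloro on the aromatic carbon ortho to a (2-carbamoylazetidin-1-yl)methyl group gives a 4.1-fold higher number from compound 2 to compound 3 (0.61 log units; beyond the scatter), the first step here that isolates this position and shows that it responds to a change of this single heavy atom, with chloro carrying the lower number. With the methyl held constant, 2-carbamoylazetidin-1-yl in place of (1-carbamoylethyl)amino gives an at least 1.1-fold lower number from compound 1 to compound 3 (0.06 log units; that floor lies within the scatter), and that floor allows no ordering of the two compounds. Compound 1 stands at a limit of the assay rather than at a number: the limit of > 10000 nM in this assay, at which 1 of the 3 values shown sits.

The compounds shown leave open why chloro gives the lower number and how a hydrogen, a fluoro, a methoxy or a nitrile on this carbon would compare. They also leave open whether the step from chloro to methyl would be the same size with the (1-carbamoylethyl)amino group in place of 2-carbamoylazetidin-1-yl.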